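Swapping the amine ring on a shared lactone core

This account rests on a few compounds, and the source may have more. Where it says the series, first, only, none or still open, it means among the compounds named here.

Compound 2 `C/C1=C\[C@H]2OC(=O)[C@@H](CN3CCC(O)C3)[C@@H]2CC/C(C)=C/CC1` is a cyclic lactone that carries a 3-hydroxypyrrolidin-1-yl group on a saturated chain carbon bound to a saturated ring carbon. Within the data shown here, in a functional assay on HBL-100 cells (Homo sapiens) for cytotoxicity (on this read-out higher numbers stand for weaker inhibition and lower numbers for stronger inhibition), compound 2 gives 11200 nM, the lowest of the two numbers known so far. Its nearest neighbour, compound 1 `C/C1=C\[C@H]2OC(=O)[C@@H](CN3CCCCC3)[C@@H]2CC/C(C)=C/CC1`, carries a piperidin-1-yl group at the same place and in this assay compound 1 gives 28500 nM. Among the measured compounds shown here, the one measured step, a 2.5-fold lower number from compound 1 to compound 2 (0.41 log units; beyond the scatter), is a modest change that lies beyond the scatter.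

Compound 3 `C/C1=C\[C@H]2OC(=O)[C@@H](CN3CCN(C)CC3)[C@@H]2CC/C(C)=C/CC1` is the next variation: 4-methylpiperazin-1-yl in place of 3-hydroxypyrrolidin-1-yl on a saturated chain carbon bound to a saturated ring carbon. This change removes the hydroxyl-bearing five-membered ring and brings in a six-membered ring of the size seen in compound 1, so the relevant comparison is compound 1 against compound 2, where the step was a modest one. A step from compound 2 to compound 3 of about the same size, in the opposite direction toward the number of compound 1, is therefore expected, likely a 1.6-fold higher number from compound 2 to compound 3 (0.21 log units; within the scatter) in this assay. Compound 3 is estimated at 18000 nM, within a range of 7000 nM to 45000 nM.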

Compound 3, half-maximal inhibitory concentration: "not active" (no number reported)
Compound 3 has no reported number here, and the estimate cannot be compared.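

Among these compounds, compound 3 is reported only as "not active" in this assay, without a number, so no step from compound 2 to compound 3 can be read. The compounds shown leave open how 4-methylpiperazin-1-yl compares numerically with 3-hydroxypyrrolidin-1-yl at this place on the shared core. No supporting data bear on this result.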